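The compounds below may be only part of what the source reports. "The series", "measured", "known", "first", "only" and "open" are said of these compounds alone.

Measured so far in a functional assay on MES-SA cells (Homo sapiens) for inhibition, with a stated time of 72 h; on this read-out lower numbers stand for stronger inhibition and higher numbers for weaker inhibition

compound 1 `Oc1c(C(c2cccnc2)N2CCCC2)ccc2cccnc12` gives 40700 nM
compound 2 `Oc1c(C(c2ccncc2)N2CCCC2)ccc2cccnc12` gives 5890 nM
compound 3 `Oc1c(C(c2cccnc2)N2CCCCC2)ccc2cccnc12` gives 13500 nM

Compound 3 holds the middle place, with 13500 nM lying under the number of compound 1 and over that of compound 2. Moving on to compound 4 `Oc1c(C(c2ccncc2)N2CCCCC2)ccc2cccnc12` keeps the same atoms but joins them differently, and the change is pyridin-4-yl in place of pyridin-3-yl on a saturated chain carbon bound to an amine nitrogen in a ring and an aromatic carbon in the shared frame. The same exchange has been measured once, on the pyrrolidin-1-yl member, as a 6.9-fold lower number from compound 1 to compound 2 (0.84 log units; beyond the scatter) and this is the step that bears most directly. The other measured step, a 3.0-fold lower number from compound 1 to compound 3 (0.48 log units; beyond the scatter), shows what piperidin-1-yl in place of pyrrolidin-1-yl does with pyridin-3-yl present. One pair cannot show whether the exchange keeps its full size on a piperidin-1-yl compound, so a lower number is expected in this assay, probably by somewhat less. The expected step is a 5.2-fold lower number from compound 3 to compound 4 (0.72 log units; beyond the scatter) in size. For compound 4 the estimated value is 2600 nM, with an expected range from 850 nM to 8000 nM as its limits.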

Compound 4, half-maximal inhibitory concentration: 15500 nM
The estimate for compound 4 lay 6.0-fold (0.78 log units) below the measured number; measured number above the stated range.
By their numbers in this assay, from the lowest: compound 2; then compounds 3 and 4 (each within the scatter of the next); then compound 1.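

In this assay, pyridin-4-yl in place of pyridin-3-yl does not carry over from the pyrrolidin-1-yl pair to the piperidin-1-yl pair, where it gives a 1.1-fold higher number from compound 3 to compound 4 (0.06 log units; within the scatter), so the effect of this exchange depends on the ring amine on the same carbon: the same change on two cores in this assay, a 6.9-fold lower number (0.84 log units; beyond the scatter) from compound 1 to compound 2 and a 1.1-fold higher number (0.06 log units; within the scatter) from compound 3 to compound 4, 7.9-fold (0.90 log units) apart, beyond the scatter of two such steps

Read the other way, piperidin-1-yl in place of pyrrolidin-1-yl gives a 2.6-fold higher number from compound 2 to compound 4 (0.42 log units; beyond the scatter), so this change reverses direction when pyridin-4-yl is present: the same change on two cores in this assay, a 3.0-fold lower number (0.48 log units; beyond the scatter) from compound 1 to compound 3 and a 2.6-fold higher number (0.42 log units; beyond the scatter) from compound 2 to compound 4, 7.9-fold (0.90 log units) apart, beyond the scatter of two such steps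

In these four compounds, then, the two changes do not simply add up.

The compounds shown leave open whether the lower number with pyridin-4-yl is confined to pyrrolidin-1-yl. A morpholine or a dimethylamino group in the same place, or a phenyl ring in place of the pyridine, would help to show how far this dependence extends.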